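The source may hold more compounds than are shown below. What is called first, only, known or untested is meant among the compounds shown, and "the series" means these compounds.

Working notes on the series. Three compounds have been run in an ADME assay on cells (Homo sapiens) for cytotoxicity; a lower number here means that less compound is tolerated, a higher number that more compound is tolerated. Compound 1 `O=C1N(Cc2cccc(COc3ccc(-c4ccc(Cl)cc4)cc3)n2)CCN1c1ccncc1` gives only a limit of the assay, > 25000 nM. Compound 3 `Cc1cc(COc2ccc(-c3ccc(Cl)cc3)cc2)cc(CN2CCN(c3ccncc3)C2=O)c1` likewise gives only a limit, > 25000 nM. Compound 2 `O=C1N(CCC(CCOc2ccc(-c3ccc(Cl)cc3)cc2)C(F)(F)F)CCN1c1ccncc1` stands at a limit as well, with > 12500 nM, so no number is known for it; the three values split between the limit of > 12500 nM in this assay, at which 1 of the 3 values shown sits, and (the limit of > 25000 nM in this assay, at which 2 of the 3 values shown sit), and no order among them can be read. Compound 4 `CC(CCOc1ccc(-c2ccc(Cl)cc2)cc1)CCN1CCN(c2ccncc2)C1=O` is the next member: methyl in place of trifluoromethyl on a saturated chain carbon bound to two saturated chain carbons. Going by the values given here, no measured step exists to lean on, so in this assay no step beyond the scatter is expected from compound 2 to compound 4, and most likely again only a limit. Compound 4 is estimated at 25000 nM, within 12500 nM to 60000 nM, implying a step that the limit leaves unreadable from compound 2 to compound 4.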

Compound 4, half-maximal cytotoxic concentration: > 25000 nM
Compound 4: only a limit was reported; the forecaster's own chance of this, stated with the estimate: 80%; the middle value lies on the limit itself.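

Going by these compounds alone, compound 2 and compound 4 both give only limits in this assay, and no step between them can be read. The compounds shown leave open whether methyl in place of trifluoromethyl changes cytotoxicity at all, and at what concentration any of them becomes cytotoxic.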